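A few compounds are considered here, and "the series" means these few. Any claim that something is new, unique, unknown or untested is made for them only; others in the source may bear on it.

Measured compounds in a functional assay on U2OS cells (Homo sapiens) for antiproliferative activity, read by MTT assay, with a stated time of 72 h; a higher number here means a weaker inhibitor, a lower number a stronger inhibitor:

compound 1 `CCOC1=C(C(=O)c2ccccc2)C(c2ccc(Br)cc2)N(CCCn2ccnc2)C1=O` — 21900 nM
compound 2 `Cc1ccc(NC2=C(C(=O)c3ccccc3)C(c3ccc(Br)cc3)N(CCCn3ccnc3)C2=O)cc1` — 24100 nM
compound 3 `CCOc1ccc(NC2=C(C(=O)c3ccccc3)C(c3ccc(Br)cc3)N(CCCn3ccnc3)C2=O)cc1` — 26200 nM

Compound 3 stands at the upper end of the three numbers, but only nominally: a 1.1-fold higher number from compound 2 to compound 3 (0.04 log units; within the scatter) and a 1.2-fold higher number from compound 1 to compound 3 (0.08 log units; within the scatter), so the three compounds cannot be separated in this assay. The shared core of compound 1 carries an ethoxy group on a double-bonded ring carbon; in compound 2 and compound 3 an arylamino group takes that place, and a 1.1-fold higher number from compound 1 to compound 2 (0.04 log units; within the scatter).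

Compound 4 `O=C(C1=C(Nc2ccccc2Br)C(=O)N(CCCn2ccnc2)C1c1ccc(Br)cc1)c1ccccc1` keeps the arylamino pattern and alters only the aryl group: 2-bromophenyl in place of 4-ethoxyphenyl on an amine nitrogen. Within the data shown here, three measured steps bear on this. The two exchanges of ethoxy for an arylamino group were both within the scatter, and the exchange of methyl for ethoxy on the aromatic carbon of that aryl group, a 1.1-fold higher number from compound 2 to compound 3 (0.04 log units; within the scatter), was likewise within the scatter. Among the measured compounds shown here, nothing measured so far shows that the identity of the substituent on the arylamino ring moves the number, and no measured step tests a bromo group or a substituent set at the 2-position of that ring. The expectation is therefore no step beyond the scatter, a 1.0-fold lower number from compound 3 to compound 4 (0.02 log units; within the scatter).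

Compound 4 is estimated at 25000 nM in this assay, with a range of 10000 nM to 60000 nM.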

Compound 4, half-maximal inhibitory concentration: 16900 nM
Compound 4: middle estimate off by 1.5-fold (0.17 log units), on the high side, and the stated range covers the measured number.
By their numbers in this assay, from the lowest: compounds 4, 1, 2 and 3 (each within the scatter of the next).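

In this assay, 2-bromophenyl on the amine nitrogen gives a 1.6-fold lower number from compound 3 to compound 4 (0.19 log units; within the scatter) against 4-ethoxyphenyl and a 1.4-fold lower number from compound 2 to compound 4 (0.15 log units; within the scatter) against 4-methylphenyl, so this position now holds a halogen-bearing aryl group as well as the two ether- and alkyl-bearing ones, and none of the three can be told apart from the others. The wider exchange at the double-bonded ring carbon, (2-bromophenyl)amino in place of ethoxy, gives a 1.3-fold lower number from compound 1 to compound 4 (0.11 log units; within the scatter), so this third arylamino group also cannot be separated from the ethoxy compound, and all four compounds remain one group in this assay. No measurement is available that would explain these numbers.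

On these data alone, in the exchanges to compound 4, the identity of the substituent and its place on the aryl ring differ together, so the effect of each alone remains open. Also open, as far as these compounds go, is whether a carboxylic acid or a dimethylamino group on that aryl ring, or a plain alkyl chain in place of the aryl group on the amine nitrogen, would produce a step beyond the scatter.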